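Pyridin-3-yl for 4-chlorophenyl on the cyclopropane carbon

This account rests on a few compounds, and the source may have more. Where it says the series, first, only, none or still open, it means among the compounds named here.

Compound 1 `N[C@@H](CC1CCCCC1)CN(C(=O)[C@@H]1C[C@H]1c1ccccc1)c1ccc(-c2ccccc2)cc1` and compound 2 `CC[C@H](C)[C@H](N)CN(C(=O)[C@@H]1C[C@H]1c1ccc(Cl)cc1)c1ccc(-c2ccccc2)cc1` share one core. In a functional assay for agonist activity at G protein-coupled receptor 88 (Homo sapiens), read by HTRF and cAMP accumulation (on this read-out lower numbers stand for an effect already at smaller amounts and higher numbers for an effect only at larger amounts of compound), compound 1 gives 1.7 nM, while compound 2 gives 4300 nM, the highest of the two numbers and separated from compound 1 by a gap well beyond the scatter. Compound 3 `CC[C@H](C)[C@H](N)CN(C(=O)[C@@H]1C[C@H]1c1cccnc1)c1ccc(-c2ccccc2)cc1` departs from compound 2 by pyridin-3-yl in place of 4-chlorophenyl on a saturated ring carbon. Going by the values given here, no measured pair shows this change, so no step is known for it; the expected step of a 1.4-fold higher number from compound 2 to compound 3 (0.14 log units; within the scatter) is a modest move toward higher numbers, barely beyond the scatter. For compound 3 the expected value in this assay is 6000 nM, with a range from 1500 nM to 25000 nM.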

Compound 3, half-maximal effective concentration: 1500 nM
The estimate for compound 3 lay 4.0-fold (0.60 log units) above the measured number, within the range that was stated.
By their numbers in this assay, from the lowest: compound 1; then compound 3; then compound 2.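

At this saturated ring carbon of the three-membered ring, pyridin-3-yl in place of 4-chlorophenyl gives, in this assay, a 2.9-fold lower number from compound 2 to compound 3 (0.46 log units; beyond the scatter). The carbon therefore accepts an aromatic ring with one hetero atom and one hydrogen-bond acceptor, with no loss on the read-out. No measurement at hand accounts for this step.

As far as these compounds go, whether the step follows from the ring nitrogen entering or from the chlorine leaving stays open. So does the reading of pyridin-4-yl or pyrimidin-5-yl at this carbon.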